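Working notes on an aryl swap along the alkenyl chain

The source may hold more compounds than are shown below. What is called first, only, known or untested is meant among the compounds shown, and "the series" means these compounds.

Compound 1 `COc1cccc(/C=C/C[C@H]2C[C@@H]([C@@H](O)c3ccccc3)CO[C@@H]2c2ccccc2)c1` serves as the reference. In a functional assay on HeLa cells (Homo sapiens) for cytotoxicity, read by WST assay, with a stated time of 48 h (on this read-out higher numbers stand for weaker inhibition and lower numbers for stronger inhibition), compound 1 gives 10900 nM, the lowest of the two numbers in hand. Compound 3 `COc1ccc([C@H]2OC[C@H]([C@@H](O)c3ccc(OC)c(OC)c3)C[C@@H]2C/C=C/c2ccc(OC)c(OC)c2)cc1` gives 46700 nM in this assay, a gap beyond the scatter. One further entry is only a limit of the assay: the limit of > 100000 nM in this assay, at which 1 of the 3 values shown sits. That entry belongs to compound 2 `COc1ccc(/C=C/C[C@@H]2C[C@@H]([C@@H](OC)c3ccc(OC)c(OC)c3)CO[C@H]2c2ccc(OC)c(OC)c2)cc1OC`, reported as > 100000 nM.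

Compound 4 `O[C@@H](c1ccccc1)[C@H]1CO[C@H](c2ccccc2)[C@@H](C/C=C/c2ccc(F)cc2)C1` has not been measured. It differs from compound 1 by 4-fluorophenyl in place of 3-methoxyphenyl on a double-bonded chain carbon bound to a double-bonded chain carbon. Among the compounds with values here, no measured pair in the set shows this change, so no step size is known for it. A step from compound 1 to compound 4 of a 1.2-fold lower number from compound 1 to compound 4 (0.08 log units; within the scatter) is expected, within the scatter. Compound 4 is estimated at 9000 nM, with a range from 3000 nM to 30000 nM.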

Compound 4, half-maximal inhibitory concentration: 8340 nM
Compound 4: the middle estimate sits 1.1-fold (0.03 log units) above what was measured; low and high end bracket the measured number.
By their numbers in this assay, from the lowest: compounds 4 and 1 (each within the scatter of the next); then compound 3. At a limit, above all of these: compound 2.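

Replacing 3-methoxyphenyl with 4-fluorophenyl on a double-bonded chain carbon bound to a double-bonded chain carbon gives a 1.3-fold lower number from compound 1 to compound 4 (0.12 log units; within the scatter) in this assay. This first single-place pair in the series shows that, on the core of compound 1, the 3-methoxyphenyl group is not needed to keep the number at this level. Nothing shown gives a reason for this step.

Going by these compounds, whether 4-fluorophenyl would behave alike on the core of compound 3 remains open. So does the reading for an aminophenyl or carboxyphenyl group at this place.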